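The source may report more compounds than this note shows. Statements on the series, on what has been measured and on what is new or still open speak of the compounds shown alone.

Values in an ADME assay on THP-1 cells (Homo sapiens) for cytotoxicity; on this read-out lower numbers stand for higher toxicity in this test and higher numbers for lower toxicity in this test:
- compound 1 `COC(=O)Nc1sc2c(c1C(=O)Nc1ccc(OC)cc1)CCCCC2`: > 50000 nM, a limit of the assay
- compound 2 `O=C(Nc1ccc(C(F)(F)F)cc1)c1c(NC(=O)C(F)(F)F)sc2c1CCCCC2`: 17200 nM
- compound 3 `O=C(Nc1ccc(OC(F)(F)F)cc1)c1c(NC(=O)C(F)(F)F)sc2c1CCCCC2`: 11900 nM

Only compound 2 and compound 3 give numbers, and these two sit within the scatter of each other: a 1.4-fold lower number from compound 2 to compound 3 (0.16 log units; within the scatter). The remaining reference point is the limit of > 50000 nM in this assay, at which 1 of the 3 values shown sits, which is a limit and not a number.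

Compound 4 `COc1ccccc1NC(=O)c1c(NC(=O)C(F)(F)F)sc2c1CCCCC2` has 2-methoxyphenyl in place of 4-(trifluoromethyl)phenyl on an amide-type nitrogen. Within the data shown here, no measured step covers this exact change. Among the measured compounds shown here, the closest evidence is the one step from compound 2, a 1.4-fold lower number from compound 2 to compound 3 (0.16 log units; within the scatter), which is a smaller swap of trifluoromethoxy in place of trifluoromethyl on an aromatic carbon. On that single step, no large move is expected in this assay, and the direction is only weakly held, so the range stays wide.

The expected change is a 1.2-fold higher number from compound 2 to compound 4 (0.07 log units; within the scatter), an estimate with little or no move beyond the scatter. For compound 4 the estimated value is 20000 nM, with an expected range of 8000 nM to 50000 nM.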

Compound 4, half-maximal cytotoxic concentration: > 50000 nM
Compound 4 gave a limit, no number; the forecaster's own chance of this, stated with the estimate: 15%; at least 2.5-fold (0.39 log units) between middle value and limit.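

The swap on the amide-type nitrogen moves the read-out in this assay beyond the scatter, giving an at least 2.9-fold higher number from compound 2 to compound 4 (0.46 log units; beyond the scatter), whereas the swap of trifluoromethoxy for trifluoromethyl gave only a 1.4-fold lower number from compound 2 to compound 3 (0.16 log units; within the scatter). Compound 4 gives > 50000 nM, which is a limit and not a number, so the size of its step is only a lower bound. With compound 4, the top of the measurable range now holds a further compound of the series: the limit of > 50000 nM in this assay, at which 2 of the 4 values shown sit.

The compounds shown leave open whether this move follows from the methoxy group itself or from the whole replacement of 4-(trifluoromethyl)phenyl by 2-methoxyphenyl. They also leave open how a phenyl carrying an amine or a carboxylic acid on the same amide-type nitrogen would read in this assay.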